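This account rests on a few compounds, and the source may have more. Where it says the series, first, only, none or still open, it means among the compounds named here.

Measured in a functional assay on KBVIN cells (Homo sapiens) for antiproliferative activity, read by sulforhodamine B assay, with a stated time of 3 days; on this read-out lower numbers stand for an effect already at smaller amounts and higher numbers for an effect only at larger amounts of compound:

- compound 1, `CCC1=C(O)c2c(oc(-c3ccc(CC(C)C)cc3)cc2=O)C(CC)(CC)C1=O`, gives 17.4 uM
- compound 2, `CCCOc1ccc(-c2cc(=O)c3c(o2)C(CC)(CC)C(=O)C(CC)=C3O)cc1`, gives 29.2 uM
- compound 3, `CCC1=C(O)c2c(oc(-c3ccc(Br)cc3)cc2=O)C(CC)(CC)C1=O`, gives 15.7 uM

Compound 3 sits within the scatter of both others: the step of a 1.1-fold lower number from compound 1 to compound 3 (0.04 log units; within the scatter) and the step of a 1.9-fold lower number from compound 2 to compound 3 (0.27 log units; within the scatter) are small. Compound 4, `CCC1=C(O)c2c(oc(-c3ccc(C)c(C)c3)cc2=O)C(CC)(CC)C1=O`, has not been measured; the change is 3,4-dimethylphenyl in place of 4-bromophenyl on an aromatic carbon. The relevant earlier changes at the same aromatic carbon, bromo against isobutyl a 1.1-fold lower number from compound 1 to compound 3 (0.04 log units; within the scatter) and bromo against propoxy a 1.9-fold lower number from compound 2 to compound 3 (0.27 log units; within the scatter), both stayed within the scatter, so swapping the group there has so far not moved this assay. Compound 4 is therefore expected to stay with the group, estimated at 17 uM with a range of 8 uM to 36 uM. The expected step is a 1.1-fold higher number from compound 3 to compound 4 (0.03 log units; within the scatter), none beyond the scatter.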

Compound 4, concentration for half-maximal effect: 0.71 uM
Estimate against measurement, compound 4: 24-fold (1.38 log units) above, outside the stated range (below it).
By their numbers in this assay, from the lowest: compound 4; then compounds 3, 1 and 2 (each within the scatter of the next).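

In this assay, going by these compounds alone, this position is not indifferent to its group: 3,4-dimethylphenyl in place of 4-bromophenyl gives (a 22-fold lower number from compound 3 to compound 4 (1.34 log units; beyond the scatter)), the only step beyond the scatter. The earlier exchanges of isobutyl, propoxy and bromo on the aryl ring showed no such movement, so the result depends on which aryl group sits next to the ring oxygen. No measurement shown accounts for the size of this step.

On these data alone, whether both methyl groups are needed or a single methyl would do remains open. So does the outcome with an amine or a carboxylic acid on this aryl ring.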